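Amide aryl swap toward a chloropyridinyl on the shared core

The source may report more compounds than this note shows. Statements on the series, on what has been measured and on what is new or still open speak of the compounds shown alone.

Working notes on the series. Compound 1 `Cc1nc(C(=O)Nc2ccc(Cl)c(-c3nnc4c(Cl)cccn34)c2)cs1` in a functional assay on A549 cells (Homo sapiens) for antiproliferative activity, read by MTT assay, with a stated time of 72 h (a lower number here means a stronger inhibitor, a higher number a weaker inhibitor), gives > 100000 nM, which is a limit of the assay rather than a number (the limit of > 100000 nM in this assay, at which 1 of the 3 values shown sits). Compound 2 `O=C(Nc1ccc(Cl)c(-c2nnc3c(Cl)cccn23)c1)c1cccc(Cl)c1` gives 52700 nM in this assay. Compound 3 `O=C(Nc1ccc(Cl)c(-c2nnc3c(Cl)cccn23)c1)c1ccon1` gives 42700 nM in this assay, the lowest of the two numbers, with compound 2 nearest at a 1.2-fold lower number from compound 2 to compound 3 (0.09 log units; within the scatter). From compound 1 the change was an at least 2.3-fold lower number from compound 1 to compound 3 (0.36 log units; beyond the scatter), and an at least 1.8-fold lower number from compound 1 to compound 2 (0.27 log units; that floor lies within the scatter).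

Compound 4 `O=C(Nc1ccc(Cl)c(-c2nnc3c(Cl)cccn23)c1)c1cccnc1Cl` differs from compound 3 by 2-chloropyridin-3-yl in place of 1,2-oxazol-3-yl on a carbonyl carbon. Among the compounds with values here, the steps that bear on it are the two aryl exchanges on the carbonyl carbon: a 1.2-fold lower number from compound 2 to compound 3 (0.09 log units; within the scatter), where a six-membered chlorinated ring stood against the five-membered ring, and an at least 1.8-fold lower number from compound 1 to compound 2 (0.27 log units; that floor lies within the scatter). Neither the six-membered exchange nor the five-membered one moved the number beyond the scatter, so for compound 4 the expected step is a 1.1-fold higher number from compound 3 to compound 4 (0.05 log units; within the scatter) in this assay, a difference not beyond the scatter in either direction. Compound 4 is therefore estimated at 48000 nM in this assay, with a range from 15000 nM to 100000 nM.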

Compound 4, half-maximal inhibitory concentration: 35800 nM
For compound 4 the middle estimate is 1.3-fold (0.13 log units) above the measured one, within the range that was stated.
By their numbers in this assay, from the lowest: compounds 4, 3 and 2 (each within the scatter of the next). At a limit, above all of these: compound 1.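

In this assay, 2-chloropyridin-3-yl on the carbonyl carbon does not separate from either of the other two aromatic rings tested against it: a 1.2-fold lower number from compound 3 to compound 4 (0.08 log units; within the scatter) and a 1.5-fold lower number from compound 2 to compound 4 (0.17 log units; within the scatter). Against the 2-methyl-1,3-thiazol-4-yl group the exchange reads an at least 2.7-fold lower number from compound 1 to compound 4 (0.44 log units; beyond the scatter), so compound 4 joins compound 3 in a step beyond the scatter, whereas the floor for compound 2 lies within it. The size of that step is only a floor, as the value of compound 1 is a limit of the assay: the limit of > 100000 nM in this assay, at which 1 of the 4 values shown sits.

Every group shown at this position is an aromatic ring, so the effect of a saturated amine such as piperidin-4-yl or of a longer alkyl chain remains open. Also open, going by these compounds, is whether any change to the shared core outside this amide would move the numbers in this assay.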